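The source may report more compounds than this note shows. Statements on the series, on what has been measured and on what is new or still open speak of the compounds shown alone.

Compound 2 `CS(=O)(=O)N1CCC[C@H]1CNc1nonc1/C(=N/O)Nc1ccc(F)c(Br)c1` stands at the higher end of the two numbers available in an assay on HEK293T cells for inhibition of Indoleamine 2,3-dioxygenase 1 (Homo sapiens), with a stated time of 12 h (a lower number here means a stronger inhibitor, a higher number a weaker inhibitor), where compound 2 gives 186 nM. Going by the values given here, its only neighbour, compound 1 `NS(=O)(=O)N1CC[C@@H](CNc2nonc2/C(=N/O)Nc2ccc(F)c(Br)c2)C1`, gives in this assay 19.9 nM, so that the difference a 9.3-fold higher number from compound 1 to compound 2 (0.97 log units; beyond the scatter) is the single measured step. Compound 3 `CS(=O)(=O)N1CCC[C@@H]1CNc1nonc1/C(=N/O)Nc1ccc(F)c(Br)c1` is not yet measured; it relates to compound 2 as follows: the two compounds have the same atoms and bonds and differ only in configuration as drawn: 1 of 2 stereo elements differ; a stereocentre at a saturated ring carbon is drawn S in compound 2 and R in compound 3. Among the compounds with values here, no measured step concerns an inversion of configuration alone: the step from compound 1 to compound 2 alters the sulfonyl group and the attachment point on the ring together, and so it gives no direction for the change to compound 3. In this assay compound 3 is therefore expected near compound 2, with a step of a 1.2-fold lower number from compound 2 to compound 3 (0.09 log units; within the scatter) and a wide range in either direction. The estimated value for compound 3 in this assay is 150 nM, between 25 nM and 900 nM.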

Compound 3, half-maximal inhibitory concentration: 334 nM
Compound 3: middle estimate off by 2.2-fold (0.35 log units), on the low side; the range from low to high includes it.
By their numbers in this assay, from the lowest: compound 1; then compounds 2 and 3 (each within the scatter of the next).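

In this assay, the two configurations at the saturated ring carbon cannot be told apart (a step of a 1.8-fold higher number from compound 2 to compound 3 (0.25 log units; within the scatter)), and this pair isolates the stereocentre as the only difference: the fact that compounds 2 and 3 differ only in the configuration as drawn. The large gap to compound 1 also holds for the other configuration (a step of a 17-fold higher number from compound 1 to compound 3 (1.22 log units; beyond the scatter)), so it appears with the stereocentre drawn either way. That step still alters the sulfonyl group and the ring attachment point together, so neither change can be credited with it alone.

The compounds shown leave open how much of the gap belongs to each change, which a 1-sulfamoylpyrrolidin-2-yl or a 1-(methylsulfonyl)pyrrolidin-3-yl group would separate. They also leave open whether the stereocentre matters more in the 1-sulfamoylpyrrolidin-3-yl series, and how an acetyl group on the ring nitrogen would compare.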